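Amino for Methoxy: One Change on Two Different Cores

The source may hold more compounds than are shown below. What is called first, only, known or untested is meant among the compounds shown, and "the series" means these compounds.

Compound 1 `COc1ccc(-c2cc3ccccc3c(-c3cccc(OC)c3)n2)cc1` gives > 50000 nM in a functional assay on DU-145 cells (Homo sapiens) for cytotoxicity, read by CCK-8 assay and cell counting, with a stated time of 72 h (on this read-out higher numbers stand for weaker inhibition and lower numbers for stronger inhibition), and this value is a limit of the assay.
Compound 2 `COc1ccc(-c2cc3ccccc3c(-c3cccc(N)c3)n2)cc1` gives 8610 nM in this assay.
Compound 3 `COc1cccc(-c2nc(-c3ccc(OC)c(OC)c3)cc3cc(C)ccc23)c1` gives > 50000 nM in this assay, and this value too is a limit of the assay.

The change from compound 1 to compound 2 is amino in place of methoxy on an aromatic carbon. It made a step of an at least 5.8-fold lower number from compound 1 to compound 2 (0.76 log units; beyond the scatter) in this assay, with the starting point resting on (the limit of > 50000 nM in this assay, at which 2 of the 3 values shown sit), so the true size of the step is not fixed.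

Compound 4 `COc1ccc(-c2cc3cc(C)ccc3c(-c3cccc(N)c3)n2)cc1OC` is not yet measured. It relates to compound 3 as compound 2 relates to compound 1: the change is amino in place of methoxy on an aromatic carbon, and the place given for it is the same in both pairs, so this is the same change made on a different core. The difference between the two cores, compound 1 against compound 3, is not broken down here.

For compound 4, an improvement of about the earlier size is expected in this assay, namely an at least 3.3-fold lower number from compound 3 to compound 4 (0.52 log units; beyond the scatter), because compound 3 starts from > 50000 nM and the same change on compound 1 gave an at least 5.8-fold lower number from compound 1 to compound 2 (0.76 log units; beyond the scatter). Compound 4 is therefore estimated at 15000 nM, with a range from 4000 nM to 50000 nM, though the assay may again report only a limit.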

Compound 4, half-maximal inhibitory concentration: 4190 nM
Beside the measured number, compound 4's estimate is 3.6-fold (0.55 log units) above it, and the stated range covers the measured number.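

In this assay, the change from 3-methoxyphenyl to 3-aminophenyl on the core of compound 3 made a step of an at least 11-fold lower number from compound 3 to compound 4 (1.07 log units; beyond the scatter), so the lower number seen on the core of compound 1 appeared again on a second core, and the two pairs agree in direction. This does not show that the change is worth the same on both cores, and the two steps can only be set side by side: the same change on two cores in this assay, an at least 5.8-fold lower number (0.76 log units; beyond the scatter) from compound 1 to compound 2 and an at least 11-fold lower number (1.07 log units; beyond the scatter) from compound 3 to compound 4; the limit leaves it open whether they differ. The starting points, compound 1 and compound 3, are both limits and not numbers, so each step gives only a minimum, and the carry-over rests on just these two pairs: the limit of > 50000 nM in this assay, at which 2 of the 4 values shown sit.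

The compounds shown leave open whether the lower number depends on the free amino group, or whether a methylamino group, a dimethylamino group, an acetamide or a hydroxyl group in the same place would give it as well. They also leave open what the methyl group and the extra methoxy group on the core of compound 3 contribute on their own, and whether the step would hold on further cores.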